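Compound 3 to compound 4: methoxy to (oxetan-3-yl)amino

This account rests on a few compounds, and the source may have more. Where it says the series, first, only, none or still open, it means among the compounds named here.

Measured values in a functional assay on HT-29 cells (Homo sapiens) for antiproliferative activity, read by MTT assay, with a stated time of 72 h (on this read-out lower numbers stand for stronger inhibition and higher numbers for weaker inhibition), are as follows.

- Compound 1 `C=CC(=O)Nc1nc(-c2cccc(Cl)c2)cs1` gives 11000 nM
- Compound 2 `C=CC(=O)N(CC(=O)OCC)c1nc(-c2ccccc2)cs1` gives 19000 nM
- Compound 3 `C=CC(=O)N(CC(=O)OC)c1nc(-c2ccccc2)cs1` gives > 30000 nM

The entry for compound 3 in this assay is > 30000 nM and it is a limit of the assay, not a number. Its standing is thus the limit of > 30000 nM in this assay, at which 1 of the 3 values shown sits, and no exact place can be given for compound 3.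

The next compound is compound 4 `C=CC(=O)N(CC(=O)NC1COC1)c1nc(-c2ccccc2)cs1` with (oxetan-3-yl)amino in place of methoxy on a carbonyl carbon so that methoxycarbonyl becomes (oxetan-3-yl)carbamoyl.

For the measured compounds named here, one measured step bears on this group: an at least 1.5-fold higher number from compound 2 to compound 3 (0.19 log units; that floor lies within the scatter) and it changes only the ester chain. Going by the values given here, no measured compound carries a carbamoyl in place of the ester, so the exchange itself has no measured size. Going by these compounds, on that thin basis, no step beyond the scatter is expected in this assay and the direction stays open. The estimated step is a number no higher from compound 3 to compound 4 (the limit leaves the size open) and it remains uncertain. For compound 4 the estimate is 30000 nM with an expected range from 12000 nM to 70000 nM and the assay may well report only a limit.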

Compound 4, half-maximal inhibitory concentration: > 30000 nM
Compound 4: no number, only a limit; the forecaster's own chance of this, stated with the estimate: 55%; the middle value lies on the limit itself.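

In this assay compound 4 gives > 30000 nM, which is a limit of the assay and not a number. The step between the limits of compound 3 and compound 4 cannot be read, so the exchange of methoxy for (oxetan-3-yl)amino on a carbonyl carbon has no measurable size, while the exchange of ethoxy for the same group gives an at least 1.5-fold higher number from compound 2 to compound 4 (0.19 log units; that floor lies within the scatter). This is the first sign that a carbamoyl at this place, like the methyl ester, gives no number in this assay, and the printed floor of the step from the ethyl ester does not go beyond the scatter: the limit of > 30000 nM in this assay, at which 2 of the 4 values shown sit.

Going by these compounds, how far compound 3 and compound 4 lie past the limit stays open, and with it any ranking of the methyl ester against the (oxetan-3-yl)carbamoyl group. Also open, on these data alone, is whether a carboxylic acid, a longer ester chain such as a butyl ester, or a plain dimethylamino group on the same carbonyl carbon would return a measurable value in this assay.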